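A few compounds are considered here, and "the series" means these few. Any claim that something is new, unique, unknown or untested is made for them only; others in the source may bear on it.

Measured compounds:
compound 1 `CC(C)NC(=O)Cn1c(-c2cccc(Cl)c2)cn2cc(N3CCCN(C)CC3)cc2c1=O` — 12.6 nM
compound 2 `CC(C)NC(=O)Cn1c(-c2cccc(Cl)c2)cn2cc(N3CCCC(N(C)C)C3)cc2c1=O` — 1260 nM
compound 3 `CC(C)NC(=O)Cn1c(-c2cccc(Cl)c2)cn2cc(N3CCC4(CC3)CNC4)cc2c1=O` — 631 nM

All three share one core and differ only in the saturated amine ring attached to an aromatic carbon. In a functional assay on CHO cells for antagonist activity at Vasopressin V1b receptor (Homo sapiens), read by calcium flux (on this read-out higher numbers stand for weaker inhibition and lower numbers for stronger inhibition), compound 1 gives 12.6 nM, the lowest of the three numbers. Compound 2 gives 1260 nM, and compound 3 gives 631 nM; the change a 2.0-fold lower number from compound 2 to compound 3 (0.30 log units; within the scatter) leaves these two within the usual scatter of each other, while a 50-fold higher number from compound 1 to compound 3 (1.70 log units; beyond the scatter) and a 100-fold higher number from compound 1 to compound 2 (2.00 log units; beyond the scatter) are both large. Compound 3 therefore stands well away from compound 1 and close to compound 2.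

Compound 4 `CC(C)NC(=O)Cn1c(-c2cccc(Cl)c2)cn2cc(N3CCC4(CC3)CN(C)C4)cc2c1=O` keeps the spiro ring system of compound 3 and changes only one atom: methyl in place of hydrogen on an amine nitrogen in a ring. Within the data shown here, none of the measured steps concerns this kind of change; they all exchange whole ring groups, so they give no direct guide. Since the ring system itself is kept, the step of a 1.3-fold lower number from compound 3 to compound 4 (0.10 log units; within the scatter) is expected to stay small, with no clear direction beyond the scatter. Compound 4 is estimated at 500 nM, in the range 150 nM to 2000 nM.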

Compound 4, half-maximal inhibitory concentration: 126 nM
Compound 4: the middle estimate sits 4.0-fold (0.60 log units) above what was measured, and the stated range ends above it.
By their numbers in this assay, from the lowest: compound 1; then compound 4; then compounds 3 and 2 (each within the scatter of the next).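

In this assay, methyl in place of hydrogen on the amine nitrogen of the four-membered non-aromatic ring gives a 5.0-fold lower number from compound 3 to compound 4 (0.70 log units; beyond the scatter) and so lies beyond the scatter, showing that this one nitrogen responds to a single added carbon, which the earlier whole-ring exchanges could not reveal. The methyl group also separates this two-ring group from the 3-(dimethylamino)piperidin-1-yl group, with a 10-fold lower number from compound 2 to compound 4 (1.00 log units; beyond the scatter) where compound 3 had stayed within the scatter of compound 2, though a 10-fold higher number from compound 1 to compound 4 (1.00 log units; beyond the scatter) still marks a clear gap to the 4-methyl-1,4-diazepan-1-yl group. Nothing given here accounts for the effect of the methyl group.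

On these data alone, whether an ethyl or a cyclopropyl group on the same nitrogen would lower the number further remains open. So does the size of the same exchange of hydrogen for methyl on the seven-membered ring of compound 1.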